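Adding a Second Chloro Group: Effect on Growth Inhibition

The source may hold more compounds than are shown below. What is called first, only, known or untested is meant among the compounds shown, and "the series" means these compounds.

The study compares four compounds that share a chlorinated bicyclic core carrying a benzyl group with a chloromethyl substituent, and were tested in a functional assay on DU-145 cells (Homo sapiens) for cytotoxicity, read by sulforhodamine B assay, with a stated time of 48 h; a higher number here means a weaker inhibitor of growth, a lower number a stronger inhibitor of growth. Compound 1 `ClCc1cccc(Cn2cnc3c(Cl)ncnc32)c1` gives 11200 nM in this assay. Compound 2 `ClCc1cccc(Cn2cnc3c(Cl)nc(Cl)nc32)c1` differs from compound 1 by one change, (chloro in place of hydrogen on an aromatic carbon), and in this assay compound 2 gives 1580 nM, so that the step is a 7.1-fold lower number from compound 1 to compound 2 (0.85 log units; beyond the scatter).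

Compound 3 `ClCc1ccccc1Cn1cnc2ncnc(Cl)c21` has the same atoms as compound 1 joined differently; the difference between the two cores is not broken down here. In this assay compound 3 gives 2950 nM, which is within the scatter of compound 2 and beyond the scatter of compound 1.

Compound 4 `ClCc1ccccc1Cn1cnc2nc(Cl)nc(Cl)c21` has not yet been measured. It is related to compound 3 by chloro in place of hydrogen on an aromatic carbon, and the place where the chloro group enters is described in the same words as for the change from compound 1 to compound 2, so the two changes are the same. Within the data shown here, on that basis a step of similar size is expected in this assay, tempered somewhat because a 7.1-fold lower number from compound 1 to compound 2 (0.85 log units; beyond the scatter) is the only measured instance of this change. The expected step is a 4.5-fold lower number from compound 3 to compound 4 (0.66 log units; beyond the scatter). Accordingly compound 4 is estimated to give about 650 nM in this assay, expected to fall between 250 nM and 1700 nM.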

Compound 4, concentration for 50% growth inhibition: 5490 nM
For compound 4 the middle estimate is 8.4-fold (0.93 log units) below the measured one, outside the stated range (above it).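

On the core of compound 3, chloro in place of hydrogen on an aromatic carbon, between two ring nitrogen atoms, gives a 1.9-fold higher number from compound 3 to compound 4 (0.27 log units; within the scatter) in this assay, so this pair cannot be told apart in that assay. The change therefore did not carry over from the core of compound 1 to the core of compound 3, and the two cores respond to it differently: the same change on two cores in this assay, a 7.1-fold lower number (0.85 log units; beyond the scatter) from compound 1 to compound 2 and a 1.9-fold higher number (0.27 log units; within the scatter) from compound 3 to compound 4, 13-fold (1.12 log units) apart, beyond the scatter of two such steps. Among these compounds, this shows that, within these four compounds, the size of the step on one core is no guide to its size on the other, but with only one pair on each core it does not show why they diverge, nor whether either step would hold for other members.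

On these data alone, the two cores have the same atoms joined differently, so it remains open which part of that difference separates the two steps. As far as these compounds go, it also remains open whether an amine or a methoxy group entering at the same ring carbon would follow the pattern of compound 2 or that of compound 4, and whether a hydroxymethyl group in place of the chloromethyl group would alter the comparison.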